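Aryl-ketone variation on a shared bicyclic core

The compounds below may be only part of what the source reports. "The series", "measured", "known", "first", "only" and "open" are said of these compounds alone.

Three compounds of the series have a result in a functional assay on A-375 cells (Homo sapiens) for cytotoxicity, read by MTT assay, with a stated time of 48 h; on this read-out lower numbers stand for stronger inhibition and higher numbers for weaker inhibition. Compound 1 `CC1(C)S[C@@H]2/C(=C\C(=O)c3cc(F)cc(F)c3)C(=O)N2[C@H]1C(=O)OC(c1ccccc1)c1ccccc1` gives 19100 nM and holds the highest of the two numbers; its nearest neighbour is compound 2 `CC1(C)[C@H](C(=O)OC(c2ccccc2)c2ccccc2)N2C(=O)/C(=C/C(=O)c3ccccc3)[C@H]2S1(=O)=O`, which gives 17500 nM, and the gap between the two lies within the scatter, so no order is drawn from it. Compound 3 `COC(=O)/C=C1\C[C@H]2SC(C)(C)[C@H](C(=O)OC(c3ccccc3)c3ccccc3)N2C1=O` reaches only the assay limit, > 100000 nM, and that is a limit and not a number; it coincides with the limit of > 100000 nM in this assay, at which 1 of the 3 values shown sits.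

Compound 4 `CC1(C)S[C@@H]2/C(=C\C(=O)c3ccc([N+](=O)[O-])cc3)C(=O)N2[C@H]1C(=O)OC(c1ccccc1)c1ccccc1` is the unmeasured member. It differs from compound 1 by 4-nitrophenyl in place of 3,5-difluorophenyl on a carbonyl carbon. For the measured compounds named here, no pair of measured compounds spans a change of this kind, so the step carries no precedent here. The measured compounds that keep the aryl ketone, compound 1 and compound 2, sit close together, which supports expecting only a small step, if any. The step from compound 1 to compound 4 is therefore estimated as a 1.3-fold lower number from compound 1 to compound 4 (0.10 log units; within the scatter), not beyond the scatter in either direction. Compound 4 is accordingly expected at 15000 nM, with a range from 5000 nM to 50000 nM.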

Compound 4, half-maximal inhibitory concentration: 50300 nM
Estimate against measurement, compound 4: 3.4-fold (0.53 log units) below; measured number above the stated range.
By their numbers in this assay, from the lowest: compounds 2 and 1 (each within the scatter of the next); then compound 4. At a limit, above all of these: compound 3.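

In this assay, the aryl group on the carbonyl carbon turns out to matter for the read-out: a 2.6-fold higher number from compound 1 to compound 4 (0.42 log units; beyond the scatter). For the compounds shown here, the earlier compounds held no step at this position, so this pair is the first reading of it, and it shows that 4-nitrophenyl in place of 3,5-difluorophenyl gives a modest change rather than a silent swap. Nothing in the data shown accounts for the direction or size of this step.

On these data alone, one pair cannot separate the departure of the 3,5-difluorophenyl from the arrival of the 4-nitrophenyl, so the contribution of each remains open. Also open, as far as these compounds go, is how the result responds on the core of compound 1 to an unsubstituted phenyl, or to a phenyl carrying an amine or a carboxylic acid, at this same carbonyl carbon.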